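Swapping the sulfonyl aryl group in an inactive hydrazide

This account rests on a few compounds, and the source may have more. Where it says the series, first, only, none or still open, it means among the compounds named here.

Measured so far:
Compound 1, `CC(=O)Nc1ccc(S(=O)(=O)NNC(=O)c2cccnc2Nc2ccc(Cl)cc2)cc1`, gives > 100000 nM in a functional assay on HCT-116 cells (Homo sapiens) for antiproliferative activity; a higher number here means a weaker inhibitor of growth, a lower number a stronger inhibitor of growth; this is a limit of the assay, not a number.
Compound 2, `O=C(NNS(=O)(=O)c1ccc(F)cc1)c1cccnc1Nc1ccc(Cl)cc1Cl`, gives > 100000 nM in this assay; this too is a limit, not a number.

Compound 1 thus stands at the limit of > 100000 nM in this assay, at which 2 of the 2 values shown sit. Compound 3, `O=C(NNS(=O)(=O)c1ccc(Cl)cc1Cl)c1cccnc1Nc1ccc(Cl)cc1`, differs from compound 1 by 2,4-dichlorophenyl in place of 4-acetamidophenyl on a sulfonyl sulfur. Going by the values given here, since both values shown are limits, no measured step tells how such a change acts, and the step from compound 1 to compound 3 is expected to be a number no higher from compound 1 to compound 3 (the limit leaves the size open), nothing beyond the scatter. Compound 3 is estimated at 100000 nM, ranging from 30000 nM to 300000 nM.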

Compound 3, concentration for total growth inhibition: 28800 nM
Compound 3: middle estimate off by 3.5-fold (0.54 log units), on the high side; measured number outside the range, below it.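

In this assay, the aryl group on the sulfonyl sulfur proves able to change the result: 2,4-dichlorophenyl in place of 4-acetamidophenyl gives an at least 3.4-fold lower number from compound 1 to compound 3 (0.54 log units; beyond the scatter). Compound 3 therefore gives a real number rather than a limit, so the size of this step is only partly fixed: the limit of > 100000 nM in this assay, at which 2 of the 3 values shown sit.

The change removes the acetamido group and adds two chlorines at once, so the part that matters remains unresolved. Going by these compounds, how an amine or a carboxylic acid on this phenyl ring would act also remains open.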